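Butyl to methoxy on the carbamate aryl ring

This account rests on a few compounds, and the source may have more. Where it says the series, first, only, none or still open, it means among the compounds named here.

The series shares one core; compound 1 is `C=C1C(=O)OC[C@@H]1CCOC(=O)Nc1ccc(CCCC)cc1`, its configurational partner compound 2 is `C=C1C(=O)OC[C@H]1CCOC(=O)Nc1ccc(CCCC)cc1`, and compound 3 is `C=C1C(=O)OC[C@@H]1CCOC(=O)Nc1ccc(C)c(C)c1`. In a functional assay on RAW264.7 cells (Mus musculus) for inhibition, with a stated time of 30 min (on this read-out higher numbers stand for weaker inhibition and lower numbers for stronger inhibition), compound 1 gives 1230 nM, the second highest of the three numbers: compound 3 gives 1450 nM and compound 2 gives 620 nM. Within the data shown here, the only single-point step measured, a 2.0-fold lower number from compound 1 to compound 2 (0.30 log units; within the scatter), rests on the fact that compounds 1 and 2 differ only in the configuration as drawn and stays within the scatter. Compound 4, `C=C1C(=O)OC[C@@H]1CCOC(=O)Nc1ccc(OC)cc1`, differs from compound 1 by methoxy in place of butyl on an aromatic carbon. Among the measured compounds shown here, no measured step touches that position in a single change; compound 3 carries a different aromatic substitution and its number sits close to that of compound 1, so the ring substituents seen so far have not moved this assay beyond the scatter. For compound 4 the expectation is therefore a step of about a 1.2-fold higher number from compound 1 to compound 4 (0.09 log units; within the scatter), that is, nothing beyond the scatter. Compound 4 is estimated at 1500 nM, with a range from 600 nM to 4000 nM.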

Compound 4, half-maximal inhibitory concentration: 1090 nM
Compound 4: the middle estimate sits 1.4-fold (0.14 log units) above what was measured, within the range that was stated.
By their numbers in this assay, from the lowest: compounds 2, 4, 1 and 3 (each within the scatter of the next, the first and the last beyond it).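

In this assay, among these compounds, the only single change measured at this aromatic carbon, methoxy in place of butyl, gives a 1.1-fold lower number from compound 1 to compound 4 (0.05 log units; within the scatter). The position, para to a large group, thus takes a smaller group that carries a hydrogen-bond acceptor where butyl carries none, and neither difference registers as a step beyond the scatter. No measured property bears on this step, and no cause can be assigned to it.

The comparison at this carbon covers only butyl and methoxy, both with no net charge, so an amine, a carboxylic acid or a longer chain in the same place could still separate from compound 1. On these data alone, whether the configurational comparison of compound 1 and compound 2 carries over to the methoxy series stays open, and the opposite configuration of compound 4 would address it.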